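The compounds below may be only part of what the source reports. "The series", "measured", "known", "first", "only" and "open" are said of these compounds alone.

Working notes on the series. Compound 1 `CC1CCC(=NNc2ccccc2)c2ncc(C(=O)NO)c(=O)n21` and compound 2 `CC1CCC(=NNc2ccccc2C(=O)O)c2ncc(C(=O)NO)c(=O)n21` share one core, while compound 3 `CC1CCC(N=Nc2ccccc2)=C2N(C)C=C(C(=O)O)C(=O)N21` carries another; the difference between the two cores is not broken down here. In a functional assay on the whole organism with Rattus norvegicus as the target (on this read-out lower numbers stand for an effect already at smaller amounts and higher numbers for an effect only at larger amounts of compound), compound 1 gives only a limit, > 100 umol/kg. Compound 2 likewise reaches only a limit in this assay, > 100 umol/kg. Compound 3 also stops at a limit, > 100 umol/kg. The change from compound 1 to compound 2 is carboxy in place of hydrogen on an aromatic carbon, and the step it made, a step that the two limits leave unreadable from compound 1 to compound 2, cannot be read. Compound 4 `CC1CCC(N=Nc2ccccc2C(=O)O)=C2N(C)C=C(C(=O)O)C(=O)N21` is the unmeasured member; it differs from compound 3 by carboxy in place of hydrogen on an aromatic carbon, the same change at the same place. Because the limit of > 100 umol/kg in this assay, at which 3 of the 3 values shown sit, gives no readable step for this change, the expected step that the limit leaves unreadable from compound 3 to compound 4 is set near zero. For compound 4 the estimate in this assay is 200 umol/kg, spanning 60 umol/kg to 1000 umol/kg, with a high chance that only a limit is again recorded.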

Compound 4, dose for 50% inhibition: > 100 umol/kg
Compound 4: only a limit was reported; the forecaster's own chance of this, stated with the estimate: 80%; the middle value is on the limit's open side.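

In this assay no step can be read from compound 3 to compound 4, both values being limits: the limit of > 100 umol/kg in this assay, at which 4 of the 4 values shown sit. The compounds shown leave open whether carboxy in place of hydrogen on an aromatic carbon changes the effect on either core, and how the two cores compare.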